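Fluorophenyl Ketone Follows Thienyl Analogue in Cytotoxicity Series

The source may hold more compounds than are shown below. What is called first, only, known or untested is meant among the compounds shown, and "the series" means these compounds.

Compound 1 `O=C(/C=C/c1ccc2c(c1)B(O)OC2)c1ccc(-c2ccccc2)cc1` gives 18300 nM in a toxicity assay on WI-38 cells (Homo sapiens) for cytotoxicity, read by MTT assay, with a stated time of 48 h; a higher number here means a weaker inhibitor, a lower number a stronger inhibitor.
Compound 2 `O=C(/C=C/c1ccc2c(c1)B(O)OC2)c1ccco1` gives 59000 nM in this assay.
Compound 3 `O=C(/C=C/c1ccc2c(c1)B(O)OC2)c1cccs1` gives 26000 nM in this assay.

Three ketones on the shared core have been measured in this assay. Compound 3 stands second highest of the three; its number sits close to that of compound 1, the gap between them being within the usual scatter, while the gap to compound 2 lies beyond it. Within the data shown here, the single step among them that changes only one place is a 2.3-fold lower number from compound 2 to compound 3 (0.36 log units; beyond the scatter), a modest change when a five-membered aromatic ring with one hetero atom is exchanged for another.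

Compound 4 `O=C(/C=C/c1ccc2c(c1)B(O)OC2)c1ccc(F)cc1` has not yet been measured. It differs from compound 3 in one place: 4-fluorophenyl in place of thiophen-2-yl on a carbonyl carbon. Among the measured compounds shown here, no measured step exchanges a five-membered aromatic ring for a six-membered aromatic ring of carbon only, so the step from compound 3 to compound 4 has no direct precedent. What the numbers show is that compound 1, the only six-membered aromatic ketone measured, gives 18300 nM, and compound 3 gives 26000 nM, values within the scatter of each other. The expectation is therefore a step of a 1.2-fold lower number from compound 3 to compound 4 (0.07 log units; within the scatter), essentially none beyond the scatter. Compound 4 is estimated at 22000 nM, with a range from 9000 nM to 55000 nM.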

Compound 4, half-maximal inhibitory concentration: 7600 nM
For compound 4 the middle estimate is 2.9-fold (0.46 log units) above the measured one, and the stated range ends above it.
By their numbers in this assay, from the lowest: compound 4; then compounds 1 and 3 (each within the scatter of the next); then compound 2.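

Compound 4 shows that the place on the carbonyl carbon can move the number beyond the scatter in this assay: there is a 3.4-fold lower number from compound 3 to compound 4 (0.53 log units; beyond the scatter) when 4-fluorophenyl enters for thiophen-2-yl, and a 7.8-fold lower number from compound 2 to compound 4 (0.89 log units; beyond the scatter) when it enters for furan-2-yl, which gives compound 4 the lowest number of the four ketones. Compound 1 adds a further point, since both it and compound 4 carry a six-membered aromatic ring of carbon only, yet there is a 2.4-fold lower number from compound 1 to compound 4 (0.38 log units; beyond the scatter) with fluoro in place of phenyl on an aromatic carbon, so the ring alone does not set the number and what it carries counts as well. Nothing in the data shown accounts for these steps.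

The compounds shown leave open whether fluoro is special among the groups on that ring, as the plain phenyl ketone and ketones with chloro, methoxy, an amine or a carboxylic acid on the ring do not appear here. They also leave open whether the order of the four ketones would hold with a saturated ring such as cyclohexyl on the carbonyl carbon, or in cells other than those of this one assay.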